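A Nitro Group Enters the Chain Phenyl of Compound 3

The compounds below may be only part of what the source reports. "The series", "measured", "known", "first", "only" and "open" are said of these compounds alone.

Compound 3 `O=C(NCCCCc1ccccc1)n1c(=O)oc2ccccc21` gives 64 nM in an assay on HEK293 cells for inhibition of acid ceramidase (Homo sapiens), with a stated time of 10 min (on this read-out lower numbers stand for stronger inhibition and higher numbers for weaker inhibition), the highest of the three numbers at hand. Compound 2 `O=C(NCCCCc1cccs1)n1c(=O)oc2ccccc21` gives 37 nM, and the step of a 1.7-fold higher number from compound 2 to compound 3 (0.24 log units; within the scatter) stays within the scatter. Compound 1 `O=C(NCCCCc1ccccc1)n1c(=O)oc2ccc(Br)cc21` gives 22 nM, and the step of a 2.9-fold higher number from compound 1 to compound 3 (0.46 log units; beyond the scatter) lies beyond it, though that change concerns a different substituent on the core. Compound 4 `O=C(NCCCCc1ccc([N+](=O)[O-])cc1)n1c(=O)oc2ccccc21` differs from compound 3 by nitro in place of hydrogen on an aromatic carbon. Neither measured step touches this aromatic carbon, para to a large group, so no clear direction can be drawn and no step beyond the scatter is expected. Compound 4 is therefore expected to give 60 nM (range 20 nM to 180 nM). The expected step of a 1.1-fold lower number from compound 3 to compound 4 (0.03 log units; within the scatter) stays within the scatter.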

Compound 4, half-maximal inhibitory concentration: 312 nM
Beside the measured number, compound 4's estimate is 5.2-fold (0.72 log units) below it, outside the stated range (above it).
By their numbers in this assay, from the lowest: compounds 1, 2 and 3 (each within the scatter of the next, the first and the last beyond it); then compound 4.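

Nitro in place of hydrogen on an aromatic carbon, para to a large group, gives a 4.9-fold higher number from compound 3 to compound 4 (0.69 log units; beyond the scatter) in this assay. This end of the molecule therefore responds to substitution, whereas the exchange of phenyl for thiophen-2-yl, seen as a 1.7-fold higher number from compound 2 to compound 3 (0.24 log units; within the scatter), did not show this. No measurement at hand bears on the reason for the rise. On these data alone, whether an amine or a methoxy group on this same carbon would shift the number in the same direction remains open, as does the effect of nitro when bromo is also present on the shared core.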